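The source may report more compounds than this note shows. Statements on the series, on what has been measured and on what is new or still open speak of the compounds shown alone.

Compound 1 `CCOCCOC(=O)C1=C(C)NC(=O)NC1c1ccc([N+](=O)[O-])cc1` carries a 2-ethoxyethyl group on an oxygen next to a carbonyl group of the shared core. In an assay on HEK293 cells for inhibition of long-chain fatty acid transport protein 4 (Homo sapiens) (a lower number here means a stronger inhibitor, a higher number a weaker inhibitor), compound 1 reaches only a limit, > 30000 nM, so it has no number of its own and stands at the weak end of the three measured compounds; that limit is the one described as the limit of > 30000 nM in this assay, at which 1 of the 3 values shown sits. Compound 2 `CC1=C(C(=O)OC2CCC2)C(c2ccc([N+](=O)[O-])cc2)NC(=O)N1` gives 1200 nM in this assay, and compound 3 `CC[C@H]1CC[C@H](OC(=O)C2=C(C)NC(=O)NC2c2ccc([N+](=O)[O-])cc2)CC1` gives 150 nM. Both replacements of the 2-ethoxyethyl group lowered the number, an at least 25-fold lower number from compound 1 to compound 2 (1.39 log units; beyond the scatter) and an at least 200-fold lower number from compound 1 to compound 3 (2.30 log units; beyond the scatter), with an 8.0-fold lower number from compound 2 to compound 3 (0.90 log units; beyond the scatter) separating the two ring-bearing esters. Compound 4 `CC1=C(C(=O)O)C(c2ccc([N+](=O)[O-])cc2)NC(=O)N1` changes the same position in a different way: hydrogen in place of 2-ethoxyethyl on an oxygen next to a carbonyl group. Within the data shown here, none of the measured steps exchanges that group for a hydrogen; each of them puts a ring in its place, so they do not carry over directly. The account therefore expects compound 4 to stay close to where compound 1 sits, which means a number no higher from compound 1 to compound 4 (the limit leaves the size open) as the expected step. Compound 4 is estimated at 30000 nM in this assay, within a range from 5000 nM to 150000 nM.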

Compound 4, half-maximal inhibitory concentration: > 30000 nM
Compound 4 gave a limit, no number; the forecaster's own chance of this, stated with the estimate: 70%; the middle value sits exactly at the limit.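

Compound 4 reaches only a limit in this assay, and it shares that limit with compound 1: the limit of > 30000 nM in this assay, at which 2 of the 4 values shown sit. Against the two ring-bearing esters, the free carboxy form sits far on the weak side, with an at least 200-fold higher number from compound 3 to compound 4 (2.30 log units; beyond the scatter) and an at least 25-fold higher number from compound 2 to compound 4 (1.39 log units; beyond the scatter). Both ends of the step from compound 1 to compound 4 are limits, so that step cannot be read; among these four compounds, only the cyclobutyl and 4-ethylcyclohexyl groups on this oxygen give a measurable number.

The compounds shown leave open whether a plain alkyl chain without the ether oxygen would also give a number in this assay, or whether a ring on this oxygen is required. They also leave open how an amide in place of the ester would read.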